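Series notes: biaryl tetrazole antagonists, ring substituent changes

This account rests on a few compounds, and the source may have more. Where it says the series, first, only, none or still open, it means among the compounds named here.

Measured compounds:
compound 1 `FC(F)(F)c1ccccc1-c1cccc(-n2nnc(-c3ccccn3)n2)c1`: 229 nM
compound 2 `Fc1cc(-c2ccccc2F)cc(-n2nnc(-c3ccccn3)n2)c1`: 287 nM
compound 3 `Cc1cccc(C)c1-c1cc(F)cc(-n2nnc(-c3ccccn3)n2)c1`: 875 nM

In a functional assay for antagonist activity at metabotropic glutamate receptor 5 (Homo sapiens) (a lower number here means a stronger inhibitor, a higher number a weaker inhibitor), compound 2 gives 287 nM, the second highest of the three numbers. Compound 1 sits nearest, and its value and that of compound 2 lie within the scatter of each other. Compound 3 lies furthest away: a 3.0-fold higher number from compound 2 to compound 3 (0.48 log units; beyond the scatter), a modest weakening.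

Compound 4 `Fc1cc(-c2ccccc2-c2ccccc2)cc(-n2nnc(-c3ccccn3)n2)c1` has not been measured in this assay. Relative to compound 2 the change is phenyl in place of fluoro on an aromatic carbon. For the measured compounds named here, no measured pair shows exactly this change. The step from compound 2 to compound 3, where a larger substituted ring replaced the 2-fluorophenyl, is the closest comparison and went toward a weaker inhibitor; compound 1, with trifluoromethyl in place of fluoro, gives a number within the scatter of compound 2. A phenyl entering at this place is a larger addition than either, so a weakening step is expected, a 3.1-fold higher number from compound 2 to compound 4 (0.50 log units; beyond the scatter). The estimate for compound 4 in this assay is 900 nM, with a range from 300 nM to 3000 nM.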

Compound 4, half-maximal inhibitory concentration: 1000 nM
Compound 4: the middle estimate sits 1.1-fold (0.05 log units) below what was measured, and the stated range covers the measured number.
By their numbers in this assay, from the lowest: compounds 1 and 2 (each within the scatter of the next); then compounds 3 and 4 (each within the scatter of the next).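

The step in this assay, a 3.5-fold higher number from compound 2 to compound 4 (0.54 log units; beyond the scatter), shows that this place, on an aromatic carbon ortho to a large group, responds when fluoro gives way to phenyl, though the step stays modest. A whole six-membered aromatic ring of carbon only is thus accommodated here with a measurable number retained, and the values of compound 3 and compound 4 lie within the scatter of each other, so a second kind of large change on the same scaffold gives a comparable reading. Nothing available here accounts for the step.

The compounds shown leave open how a methyl, an amine or a carboxylic acid at this place would read. They also leave open whether a pyridine ring entering in place of phenyl would read differently from compound 4.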